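The source may hold more compounds than are shown below. What is called first, only, known or untested is meant among the compounds shown, and "the series" means these compounds.

Compound 2 `C=CCc1cc(-c2ccc(O)c(CC=C)c2)c(O)c(C(c2ccc(Cl)cc2)N2CCC(C)CC2)c1` stands lowest of the two numbers obtained so far in an assay on isolated protein for inhibition of Maltase-glucoamylase (Homo sapiens), with stated times of 15 min and 10 min, tested at 64 uM; a higher number here means more inhibition at the concentration tested (going by the name of the read-out), a lower number less inhibition: in this assay compound 2 gives 8.6%, while compound 1 `C=CCc1cc(-c2ccc(O)c(CC=C)c2)c(O)c(C(c2ccc(Cl)cc2)N2CCCC2)c1` gives 40.6%. Within the data shown here, the one measured step, a number 32 percentage points lower from compound 1 to compound 2 (beyond the scatter), concerns the amine ring, not the aryl group. Compound 3 `C=CCc1cc(-c2ccc(O)c(CC=C)c2)c(O)c(C(c2cc(Cl)cc(Cl)c2)N2CCC(C)CC2)c1` differs from compound 2 by 3,5-dichlorophenyl in place of 4-chlorophenyl on a saturated chain carbon bound to an amine nitrogen in a ring and an aromatic carbon. Among the measured compounds shown here, no measured step touches this part of the core of compound 2; nothing among the numbers speaks for or against the change, and the only footing is that compound 2 already sits low in this assay. The step of a number 3.4 percentage points higher from compound 2 to compound 3 (within the scatter) is therefore expected to stay within the scatter, with no direction read into it. Compound 3 is estimated at 12% in this assay, within a range from 0% to 30%.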

Compound 3, a percentage reported as inhibition, at one concentration (the size of the read-out at that concentration, not a potency): 97.5%
For compound 3 the middle estimate is 85.5 percentage points below the measured one, and the stated range ends below it.
By their numbers in this assay, from the lowest: compound 2; then compound 1; then compound 3.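

In this assay, the aryl group on the saturated chain carbon bound to an amine nitrogen in a ring and an aromatic carbon proves highly sensitive to change: 3,5-dichlorophenyl in place of 4-chlorophenyl gives a number 88.9 percentage points higher from compound 2 to compound 3 (beyond the scatter). The low number of compound 2 therefore does not rule out the 4-methylpiperidin-1-yl ring, since with that ring kept compound 3 gives 97.5%. The change adds one chlorine and leaves the hydrogen-bond donor and acceptor counts unchanged, and no supporting measurement bears on the size of this step.

Still open, from the compounds shown here alone, is whether 3,5-dichlorophenyl gives a similar step with the pyrrolidin-1-yl ring, and whether 3,5-dimethylphenyl or plain phenyl would hold the number up. With a read-out at one concentration, the potency order of these compounds also remains open.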